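Shifting the carboxylate and branching the linker

The source may report more compounds than this note shows. Statements on the series, on what has been measured and on what is new or still open speak of the compounds shown alone.

Compound 1 `CN(Cc1cccc(C(=O)O)c1)c1ccc(OCc2c(-c3c(Cl)cccc3Cl)noc2C2CC2)nc1C(F)(F)F` and compound 2 `O=C(O)c1cccc(OCc2ccc(OCc3c(-c4c(Cl)cccc4Cl)noc3C3CC3)nc2C(F)(F)F)c1` share a core and differ in the link to the carboxyphenyl group. In a functional assay on HEK293 cells for agonist activity at Bile acid receptor (Homo sapiens), read by a luciferase reporter (on this read-out lower numbers stand for smaller maximal responses and higher numbers for larger maximal responses), compound 1 gives 43%, and compound 2 gives 41%. The step of a number 2 percentage points lower from compound 1 to compound 2 (within the scatter) lies within the scatter. On the two numbers shown, compound 2 has no lower neighbour, and the only other value, that of compound 1, lies within the scatter of it.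

Compound 3 `CC(Oc1ccc(C(=O)O)cc1)c1ccc(OCc2c(-c3c(Cl)cccc3Cl)noc2C2CC2)nc1C(F)(F)F` has not yet been measured. Compared with compound 2 it carries 1-(4-carboxyphenoxy)ethyl in place of (3-carboxyphenoxy)methyl on an aromatic carbon. Going by the values given here, the only measured step, from compound 1 to compound 2, concerns a different part of the linker and left the maximal response unchanged within the scatter; no measured step covers the movement of the carboxy group or the added methyl, so the expectation rests on the stable maximal response seen so far. Compound 3 is therefore expected to give 40%, with a range from 25% to 58%. The expected step of a number 1 percentage points lower from compound 2 to compound 3 (within the scatter) is estimated to stay within the scatter, in no clear direction.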

Compound 3, largest response reached (reported as efficacy), in percent of the reference or control that the assay uses: 33%
Beside the measured number, compound 3's estimate is 7 percentage points above it; the range from low to high includes it.
By their numbers in this assay, from the lowest: compounds 3, 2 and 1 (each within the scatter of the next).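

In this assay, the aromatic carbon ortho to a trifluoromethyl group takes 1-(4-carboxyphenoxy)ethyl in place of (3-carboxyphenoxy)methyl with a number 8 percentage points lower from compound 2 to compound 3 (within the scatter), and in place of (3-carboxybenzyl)(methyl)amino with a number 10 percentage points lower from compound 1 to compound 3 (within the scatter). The earlier pair showed only that one link to a 3-carboxyphenyl group could stand in for another, whereas this result extends that finding to a change that adds a methyl to the linker carbon and also carries the carboxylic acid at the 4-position of the phenyl ring, with all three compounds within the scatter of one another. There is no independent information here to account for these maximal responses.

The two changes in compound 3 arrive together, so the compounds shown leave open what each contributes alone; a (4-carboxyphenoxy)methyl group and a 1-(3-carboxyphenoxy)ethyl group at this position would separate them. They also leave open whether the maximal response stays in this range when the carboxylic acid is replaced, for example by a primary amide or a tetrazole.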